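A few compounds are considered here, and "the series" means these few. Any claim that something is new, unique, unknown or untested is made for them only; others in the source may bear on it.

Measured so far in a functional assay on the whole organism for antagonist activity, with Mus musculus as the target; a lower number here means that less compound is needed, a higher number that more compound is needed for the effect:
Compound 1 `CSc1nnc(-c2ccc(F)cc2)n1C`: > 200 mg/kg (a limit)
Compound 2 `CSc1nnc(-c2cccc3ccccc23)n1C`: > 200 mg/kg (a limit)

Neither compound gives a number, so the series has no measured dose yet. Compound 1 stands at the limit of > 200 mg/kg in this assay, at which 2 of the 2 values shown sit, and it shares that position with compound 2.

Compound 3 `CSc1nnc(-c2ccc(Cl)cc2)n1C` differs from compound 1 in one place, with chloro in place of fluoro on an aromatic carbon of a six-membered aromatic ring of carbon only, para to a group of 8 heavy atoms (chloro in place of fluoro on an aromatic carbon). Going by the values given here, no measured pair shows what such an exchange does in this assay. The expected step is a number no higher from compound 1 to compound 3 (the limit leaves the size open), which means none beyond the scatter and no firm direction. Another limit would be no surprise. Compound 3 is estimated at 200 mg/kg, with an expected range from 100 mg/kg to 400 mg/kg.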

Compound 3, dose for half-maximal effect: > 200 mg/kg
Compound 3 ended at the assay's limit (the forecaster's own chance of this, stated with the estimate: 65%); the middle value lies on the limit itself.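

Compound 3 and compound 1 both end at a limit, so no step between them can be read, and swapping fluoro for chloro shows no measurable consequence here: the limit of > 200 mg/kg in this assay, at which 3 of the 3 values shown sit.

What the compounds shown leave open is whether any member of this series reaches a measurable dose in this assay.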